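Replacing 5-methylpyridin-2-yl with 5-methyl-1,3-oxazol-2-yl

A few compounds are considered here, and "the series" means these few. Any claim that something is new, unique, unknown or untested is made for them only; others in the source may bear on it.

Of the compounds shown here, three have been read in an ADME assay on HEK293 cells (Homo sapiens) for cytotoxicity, read by ATP content, with a stated time of 6 h (on this read-out higher numbers stand for lower toxicity in this test and lower numbers for higher toxicity in this test), and each gave only a limit of the assay rather than a number. Compound 1 (`CCCCNc1nc(N)nc2ccn(Cc3nccs3)c12`) reads > 24000 nM. Compound 2 (`COCCNc1nc(N)nc2ccn(Cc3ccccn3)c12`) reads > 24000 nM. Compound 3 (`Cc1ccc(CNc2nc(N)nc3ccn(Cc4ccccn4)c23)nc1`) reads > 24000 nM, so it stands at the same limit and has no number of its own. Compound 4 (`Cc1cnc(CNc2nc(N)nc3ccn(Cc4ccccn4)c23)o1`) carries 5-methyl-1,3-oxazol-2-yl in place of 5-methylpyridin-2-yl on a saturated chain carbon bound to a nitrogen on an aromatic ring. Among the compounds with values here, the one measured step at this place is a step that the two limits leave unreadable from compound 2 to compound 3, so it offers no size to carry over. What remains is the limit of > 24000 nM in this assay, at which 3 of the 3 values shown sit. On that basis, no shift beyond the scatter is expected in this assay, and no direction can be named. The expected change is a step that the limit leaves unreadable from compound 3 to compound 4. For compound 4 the estimate is 30000 nM, with an expected range of 15000 nM to 60000 nM, and the assay will probably again report only a limit.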

Compound 4, half-maximal cytotoxic concentration: > 24000 nM
Compound 4 was reported as a limit; the forecaster's own chance of this, stated with the estimate: 85%; the middle value is on the limit's open side.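

In this assay compound 4 is reported only as a limit, > 24000 nM, so its steps from compound 2 and compound 3 cannot be read. The compounds shown leave open whether any of these groups changes the read-out, as all stand at one ceiling: the limit of > 24000 nM in this assay, at which 4 of the 4 values shown sit.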